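The source may report more compounds than this note shows. Statements on the series, on what has been measured and on what is new or still open speak of the compounds shown alone.

Compound 1 `Cc1cccc(Cl)c1CC1CN/C(=N\N(C)C)CN(CC(=O)Nc2cccc(-c3cnn(C)c3)c2)C1=O` is the reference point here. Among the measured compounds shown here, in an assay on isolated protein for inhibition of kallikrein-7 (Homo sapiens), read by fluorescence, with stated times of 10 min and 30 min (on this read-out higher numbers stand for weaker inhibition and lower numbers for stronger inhibition), compound 1 gives 1500 nM, the only number recorded for it, alongside one further entry that carries no single number. A close relative, compound 2 `CN(C)/N=C1/CN(CC(=O)Nc2cccc(-c3cnn(C)c3)c2)C(=O)C(Cc2c(Cl)cccc2Cl)CN1`, has repeated entries in this assay and shows 790 nM; > 30000 nM; 380 nM (3 entries). One of the entries for compound 2 is a limit of the assay rather than a number. The spread seen in the several entries of compound 2 in this assay, 790 nM; > 30000 nM; 380 nM (3 entries) shows how widely repeat readings of one compound can fall apart in this setting. Compound 3 `CN(C)/N=C1/CN(CC(=O)Nc2cccc(-c3cnn(C)c3)c2)C(=O)C(Cc2c(F)cccc2C(F)(F)F)CN1` has not yet been measured. It differs from compound 1 in one place: 2-fluoro-6-(trifluoromethyl)phenyl in place of 2-chloro-6-methylphenyl on a saturated chain carbon bound to a saturated ring carbon. For the measured compounds named here, no measured pair carries exactly this change, so the step is expected to be small, a 1.5-fold lower number from compound 1 to compound 3 (0.18 log units; within the scatter), with no direction clearly beyond the scatter. Compound 3 is therefore estimated at 1000 nM in this assay, within a range from 300 nM to 4000 nM.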

Compound 3, half-maximal inhibitory concentration: 2700 nM
Compound 3: middle estimate off by 2.7-fold (0.43 log units), on the low side; the range from low to high includes it.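

At this position, on a saturated chain carbon bound to a saturated ring carbon, putting 2-fluoro-6-(trifluoromethyl)phenyl in place of 2-chloro-6-methylphenyl gives a 1.8-fold higher number from compound 1 to compound 3 (0.26 log units; within the scatter) in this assay. The entering group has 11 heavy atoms against 8 for the group it replaces, yet the step stays within the scatter, so this larger group is accepted here without a clear loss or gain. Small steps are hard to read in this setting, and one entry for compound 2 is a limit of the assay rather than a number: the several entries of compound 2 in this assay, 790 nM; > 30000 nM; 380 nM (3 entries)

The compounds shown leave open how an unsubstituted phenyl, or a phenyl carrying an amine or a carboxylic acid, would read at this position. They also leave open whether the same exchange would give a similar step with other groups elsewhere on the shared core.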